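The compounds below may be only part of what the source reports. "The series", "measured", "known", "first", "only" and "open" are said of these compounds alone.

Notes on the aryl group on the aromatic nitrogen, as read in a functional assay on HCT-116 cells (Homo sapiens) for inhibition, read by MTT assay, with a stated time of 72 h (on this read-out higher numbers stand for weaker inhibition and lower numbers for stronger inhibition), for this series. Compound 1 (`COc1cc2c(Oc3ccc(NC(=O)c4nn(-c5ccc(F)c(Cl)c5)cc(C)c4=O)cc3)ccnc2cc1OCCCCCCC(=O)NO`) gives 370 nM and compound 2 (`COc1cc2c(Oc3ccc(NC(=O)c4nn(-c5cccc(C(F)(F)F)c5)cc(C)c4=O)cc3)ccnc2cc1OCCCCCCC(=O)NO`) gives 590 nM on this read-out. Compound 2 stands within the scatter of compound 1, so the two cannot be ranked. Compound 3 (`COc1cc2c(Oc3ccc(NC(=O)c4nn(-c5ccc(C)cc5)cc(C)c4=O)cc3)ccnc2cc1OCCCCCCC(=O)NO`) carries 4-methylphenyl in place of 3-(trifluoromethyl)phenyl on an aromatic nitrogen and has no number yet. For the measured compounds named here, one measured step bears on this exchange, the placing of 3-(trifluoromethyl)phenyl where compound 1 has 3-chloro-4-fluorophenyl. Resting on compound 2 and that step (a 1.6-fold higher number from compound 1 to compound 2 (0.20 log units; within the scatter)), which lies within the scatter, no step beyond the scatter is expected in this assay and no direction can be given, since no measured compound holds 4-methylphenyl. The expected step by this estimate is a 1.3-fold lower number from compound 2 to compound 3 (0.12 log units; within the scatter) and nothing larger is assumed. Compound 3 is estimated at 450 nM with an expected range from 180 nM to 1100 nM on this read-out.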

Compound 3, half-maximal inhibitory concentration: 400 nM
For compound 3 the middle estimate is 1.1-fold (0.05 log units) above the measured one, and the stated range covers the measured number.
By their numbers in this assay, from the lowest: compounds 1, 3 and 2 (each within the scatter of the next).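

In this assay, 4-methylphenyl in place of 3-(trifluoromethyl)phenyl gives a 1.5-fold lower number from compound 2 to compound 3 (0.17 log units; within the scatter), and 4-methylphenyl in place of 3-chloro-4-fluorophenyl gives a 1.1-fold higher number from compound 1 to compound 3 (0.03 log units; within the scatter), so compound 1, compound 2 and compound 3 cannot be ranked. Compound 1 and compound 2 both carry fluorine on the aryl group, whereas compound 3 shows that a group of 7 heavy atoms, all carbon, can stand on this aromatic nitrogen with a number that stays within the scatter of both, so fluorine on the aryl group is not needed to stay in this range of numbers in this assay. No measurement at hand explains the closeness of these three numbers.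

As far as these compounds go, all three groups are substituted phenyl rings without hydrogen-bond donors or acceptors, so it remains open whether a phenyl ring bearing an amine or a carboxylic acid, or a cyclohexyl ring in place of the aryl group, would give a step beyond the scatter. Since no substituent appears here at two ring positions, a pair such as 3-methylphenyl and 4-methylphenyl would be needed to read the effect of placement alone.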